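Compound 2 to compound 3: a change beside the nitro group

The compounds below may be only part of what the source reports. "The series", "measured", "known", "first", "only" and "open" are said of these compounds alone.

Compounds measured in a functional assay on RS4-11 cells (Homo sapiens) for inhibition, read by CCK-8 assay, with a stated time of 72 h; on this read-out lower numbers stand for stronger inhibition and higher numbers for weaker inhibition
compound 1 `CC1(C)CCC(CN2CCN(c3ccc(C(=O)NS(=O)(=O)c4ccc(NCC5CCOCC5)c([N+](=O)[O-])c4)c(Oc4cnc5[nH]ccc5c4)c3)CC2)=C(c2ccc(Cl)cc2C(F)(F)F)C1` value 74 nM
compound 2 `CN1CCC(CNc2ccc(S(=O)(=O)NC(=O)c3ccc(N4CCN(CC5=C(c6ccc(C(F)(F)F)cc6)CC(C)(C)CC5)CC4)cc3Oc3cnc4[nH]ccc4c3)cc2[N+](=O)[O-])C1` value 8.3 nM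

Compound 2 has the lower number of the two at 8.3 nM and compound 1 stands higher at 74 nM with a gap beyond the scatter between them.

Compound 3 `CC1(C)CCC(CN2CCN(c3ccc(C(=O)NS(=O)(=O)c4ccc(OCC5CCSCC5)c([N+](=O)[O-])c4)c(Oc4cnc5[nH]ccc5c4)c3)CC2)=C(c2ccc(C(F)(F)F)cc2)C1` has not yet been measured. Its difference from compound 2 is a group of 8 heavy atoms (6 carbon, 1 oxygen, 1 sulfur; one six-membered non-aromatic ring with 1 hetero atom) in place of a group of 8 heavy atoms (6 carbon, 2 nitrogen; one five-membered non-aromatic ring with 1 hetero atom), on an aromatic carbon and it lies on an aromatic carbon of a six-membered aromatic ring of carbon only, ortho to a nitro group and para to a large group. The rest of the structure is unchanged.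

Within the data shown here, no measured pair differs in one place, so the data give no direct step size. Compound 1 also carries a six-membered non-aromatic ring with 1 hetero atom in this part of the molecule and gives 74 nM in this assay but differs from compound 2 elsewhere too, which makes it only a loose guide. On that guide a rise beyond the scatter, towards weaker inhibition, is expected, estimated as a 3.6-fold higher number from compound 2 to compound 3 (0.56 log units; beyond the scatter) in this assay for this change. For compound 3 the estimated value is 30 nM with an expected range (6 nM to 150 nM).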

Compound 3, half-maximal inhibitory concentration: 15 nM
The estimate for compound 3 lay 2.0-fold (0.30 log units) above the measured number; low and high end bracket the measured number.
By their numbers in this assay, from the lowest: compounds 2 and 3 (each within the scatter of the next); then compound 1.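

In this assay, among these compounds, the step from the ((1-methylpyrrolidin-3-yl)methyl)amino group to the entering group with its six-membered non-aromatic ring with 1 hetero atom is a 1.8-fold higher number from compound 2 to compound 3 (0.26 log units; within the scatter) and is the first direct reading at this position, on an aromatic carbon ortho to a nitro group and para to a large group. The position therefore accepts a group with 0 hydrogen-bond donors and with oxygen and sulfur in place of the 2 nitrogens of the leaving group, with no change in the read-out beyond the scatter. No measurement shown here bears on the reason for this result.

This single step changes the ring, its hetero atom and the atom joining it to the aromatic carbon all at once, and it does not separate their contributions. Still open, from the compounds shown here alone, is how this position would read with a tetrahydropyranylmethylamino group on the otherwise unchanged structure of compound 3, or with a carboxylic acid or a longer chain in the same place.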